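Furan-2-yl for 2-methylphenyl: estimating compound 4

A few compounds are considered here, and "the series" means these few. Any claim that something is new, unique, unknown or untested is made for them only; others in the source may bear on it.

Compound 1 `Cc1ccccc1-c1nnc(SCCn2c([N+](=O)[O-])cnc2C)o1` is the reference point of this set. In a functional assay on HepG2 cells (Homo sapiens) for cytotoxicity, read by MTT assay, with a stated time of 48 h (a higher number here means a weaker inhibitor, a lower number a stronger inhibitor), compound 1 gives 5100 nM, which is the second highest of the three numbers measured. Its nearest neighbour is compound 2 `Cc1ncc([N+](=O)[O-])n1CCSc1nnc(-c2ccc(N)cc2)o1`, where a 1.3-fold higher number from compound 1 to compound 2 (0.12 log units; within the scatter); in this assay compound 2 gives 6700 nM. Its furthest neighbour is compound 3 `Cc1ncc([N+](=O)[O-])n1CCSc1nnc(-c2ccc(F)cc2)o1`, where an 8.5-fold lower number from compound 1 to compound 3 (0.93 log units; beyond the scatter); in this assay compound 3 gives 600 nM. Between the two substituted phenyl analogues, an 11-fold lower number from compound 2 to compound 3 (1.05 log units; beyond the scatter).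

Compound 4 `Cc1ncc([N+](=O)[O-])n1CCSc1nnc(-c2ccco2)o1` differs from compound 1 in one place: furan-2-yl in place of 2-methylphenyl on an aromatic carbon. The two measured steps that start from compound 1 both replace the 2-methylphenyl on the same aromatic carbon, one staying within the scatter and one giving a modest lower number. For the measured compounds named here, neither replaces it with a five-membered aromatic ring, so there is no direct precedent for furan-2-yl here. The measured steps leave open anything from no change to a modest lower number, and the expectation for this assay is set a little below compound 1 with a wide range, as a 1.7-fold lower number from compound 1 to compound 4 (0.23 log units; within the scatter). For compound 4 the expected value in this assay is therefore 3000 nM, with a range from 700 nM to 12000 nM.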

Compound 4, half-maximal inhibitory concentration: 22600 nM
Compound 4: middle estimate off by 7.5-fold (0.88 log units), on the low side, and the stated range ends below it.
By their numbers in this assay, from the lowest: compound 3; then compounds 1 and 2 (each within the scatter of the next); then compound 4.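

In this assay, for the compounds shown here, this aromatic carbon of the five-membered aromatic ring with 2 nitrogen and 1 oxygen now shows a change to a higher number beyond the scatter, with a 4.4-fold higher number from compound 1 to compound 4 (0.65 log units; beyond the scatter) and a 3.4-fold higher number from compound 2 to compound 4 (0.53 log units; beyond the scatter); the earlier steps from compound 1 gave either no separation or a lower number. Together with a 38-fold higher number from compound 3 to compound 4 (1.58 log units; beyond the scatter), which is the widest step in the set, this makes compound 4 the weakest of the four and compound 3 the strongest, so a single group at this carbon can shift the read-out over a broad span, and furan-2-yl lies at the weak end of it. Nothing available here explains why the five-membered ring with its oxygen behaves this way.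

Going by these compounds, whether the higher number goes with the smaller ring or with its oxygen stays open, and thiophen-2-yl or unsubstituted phenyl at this carbon would separate the two. Also open, on these data alone, is how much of the gain in compound 3 belongs to the fluoro group itself and how much to its place on the phenyl ring, a question that 2-fluorophenyl and 4-methylphenyl would address.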